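Trifluoromethyl added to the aromatic ring of compound 2

A few compounds are considered here, and "the series" means these few. Any claim that something is new, unique, unknown or untested is made for them only; others in the source may bear on it.

Compound 1 `CCc1nnc(CC)n1N`: in a functional assay on the whole organism with Mus musculus as the target (on this read-out higher numbers stand for an effect only at larger amounts of compound and lower numbers for an effect already at smaller amounts), compound 1 gives > 600 mg/kg, which is a limit of the assay and not a number.
Compound 2 `Cc1nnc(C)n1/N=C(\N)c1ccccc1`: in this assay compound 2 gives > 600 mg/kg, again a limit of the assay.
Compound 3 `Cc1ccc(C(=N)Nn2c(C)nnc2C)cc1`: in this assay compound 3 gives > 600 mg/kg, also a limit of the assay.

Compound 2 therefore stands exactly where the other two measured compounds stand, at the limit of > 600 mg/kg in this assay, at which 3 of the 3 values shown sit. Among the measured compounds shown here, none of the three gives a number, so no order among them can be drawn and no step between measured compounds can be put into figures. Compound 4 `Cc1nnc(C)n1/N=C(\N)c1ccc(C(F)(F)F)cc1` differs from compound 2 by trifluoromethyl in place of hydrogen on an aromatic carbon. For the measured compounds named here, with no measured step to build on, the step expected in this assay from compound 2 to compound 4 is none beyond the scatter, that is an estimated change of a number no higher from compound 2 to compound 4 (the limit leaves the size open). Compound 4 is thus expected to give about 600 mg/kg in this assay, within an estimated range from 300 mg/kg to 1200 mg/kg, and most probably it will again be reported only as a limit of the assay.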

Compound 4, dose for 50% inhibition: > 600 mg/kg
Compound 4: a limit, no number; the forecaster's own chance of this, stated with the estimate: 85%; the middle value lies on the limit itself.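

Compound 2 and compound 4 both end at a limit of the assay and not at a number, so no step can be read between them: the limit of > 600 mg/kg in this assay, at which 4 of the 4 values shown sit.

The compounds shown leave open what trifluoromethyl in place of hydrogen on an aromatic carbon does, and at what dose any of them would act.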